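The source may report more compounds than this note shows. Statements on the series, on what has been measured and on what is new or still open speak of the compounds shown alone.

Two cores are compared in a functional assay on the whole organism (strain Kunming) with Mus musculus as the target, with a stated time of 30 min; a higher number here means that more compound is needed for the effect, a lower number that less compound is needed. Compound 1 `CCCCCCSc1nnc(COc2ccc3c(c2)CCC(=O)N3)o1` gives 10.4 mg/kg, and compound 2 `CCCCCSc1nnc(COc2ccc3c(c2)CCC(=O)N3)o1` gives 8.9 mg/kg. The change between them is methyl in place of hydrogen on a saturated chain carbon, five bonds along the chain from a sulfur and the step is a 1.2-fold higher number from compound 2 to compound 1 (0.07 log units; within the scatter). Compound 3 `CCCCCSc1nnc(COc2ccc(-n3cnnc3)cc2)o1` carries the second core and gives 18.7 mg/kg; the difference between the two cores is not broken down here. Compound 4 `CCCCCCSc1nnc(COc2ccc(-n3cnnc3)cc2)o1` is not yet measured; it differs from compound 3 by methyl in place of hydrogen on a saturated chain carbon, five bonds along the chain from a sulfur, the same change as between compound 2 and compound 1, at a place described in the same words. For the measured compounds named here, because the one measured instance of this change gave a 1.2-fold higher number from compound 2 to compound 1 (0.07 log units; within the scatter), a step of about the same size is expected here, a 1.1-fold higher number from compound 3 to compound 4 (0.05 log units; within the scatter). Compound 4 is therefore estimated at 21 mg/kg, with a range from 12 mg/kg to 36 mg/kg.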

Compound 4, dose for half-maximal effect: 26.6 mg/kg
For compound 4 the middle estimate is 1.3-fold (0.10 log units) below the measured one; measured number inside the range.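

Under this assay the change of hydrogen to methyl on a saturated chain carbon, five bonds along the chain from a sulfur, gives a 1.4-fold higher number from compound 3 to compound 4 (0.15 log units; within the scatter) on the core of compound 3. For the compounds shown here, the two cores show no difference in this step that stands clear of the scatter: the same change on two cores in this assay, a 1.2-fold higher number (0.07 log units; within the scatter) from compound 2 to compound 1 and a 1.4-fold higher number (0.15 log units; within the scatter) from compound 3 to compound 4, 1.2-fold (0.09 log units) apart, within the scatter of two such steps. Going by these compounds alone, with both steps within the scatter and only two pairs, this shows that the change stays small on both cores, not that it has a real direction or would stay small on a further core.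

Still open, as far as these compounds go, is whether a longer chain would behave alike on both cores. The same holds for a chain carrying an amine or a carboxylic acid.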